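A few compounds are considered here, and "the series" means these few. Any claim that something is new, unique, unknown or untested is made for them only; others in the source may bear on it.

Two compounds have been measured so far:
compound 1, `O=C(O)COc1ccncc1-c1ccc2ccccc2c1`, which in an assay on a protein complex for inhibition of CDK8/Cyclin C (Homo sapiens), with a stated time of 1 h, tested at 10 uM (a lower number here means less inhibition, a higher number more inhibition at the concentration tested (going by the name of the read-out)), gives 16%;
compound 2, `CCOC(=O)/C=C/c1ccncc1-c1ccc2ccccc2c1`, which in this assay gives 102%.

Compound 2 stands highest of the two numbers, and its nearest neighbour is compound 1; the step of a number 86 percentage points higher from compound 1 to compound 2 (beyond the scatter) is well beyond the scatter, so compound 2 clearly gives the higher number of the pair in this assay.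

Compound 3, `O=C(O)/C=C/c1ccncc1-c1ccc2ccccc2c1`, has not yet been measured. It differs from compound 2 in one place: hydrogen in place of ethyl on an oxygen next to a carbonyl group. Among the compounds with values here, the only step seen so far, a number 86 percentage points higher from compound 1 to compound 2 (beyond the scatter), is the one that bears on this; it also changes a carboxy group into an ethoxycarbonyl group, though together with a change of the linking chain, so the two parts of that step cannot be separated. Going from compound 2 to compound 3 reverses the acid-to-ester part of that step. A drop in this assay is therefore expected, with the size uncertain because the step of a number 86 percentage points higher from compound 1 to compound 2 (beyond the scatter) mixes two changes. For compound 3 the estimate is 50%, between 10% and 95%, meaning an expected step of a number 52 percentage points lower from compound 2 to compound 3 (beyond the scatter).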

Compound 3, a percentage reported as inhibition, at one concentration (the size of the read-out at that concentration, not a potency): 102%
Compound 3: the middle estimate sits 52 percentage points below what was measured; measured number outside the range, above it.
By their numbers in this assay, from the lowest: compound 1; then compounds 2 and 3 (each within the scatter of the next).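

Within this assay the change from ethoxycarbonyl to carboxy at the end of the ethenyl chain gives no change at the digits printed from compound 2 to compound 3 (within the scatter) and so, on this chain, removing the ethyl group from this oxygen leaves the read-out where it was. This separates the two parts that were mixed in the earlier step: with a carboxy group present on both sides of the comparison, 2-carboxyethenyl in place of carboxymethoxy still gives a number 86 percentage points higher from compound 1 to compound 3 (beyond the scatter) and so, in these compounds, the large difference goes with the linking chain and not with the choice between acid and ester. Nothing given here accounts for either result.

Going by these compounds, compounds 2 and 3 are compared at one concentration only, and such a number is not a potency, so any difference between them at lower concentrations remains open. On these data alone, it is also open whether an amide at the end of the chain, a longer chain or a saturated ethyl link in place of the ethenyl link would keep the read-out at this level.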